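A few compounds are considered here, and "the series" means these few. Any claim that something is new, unique, unknown or untested is made for them only; others in the source may bear on it.

Compound 2 `O=S(=O)(NCCCCNCc1ccc(Br)cc1)c1cc(C(F)(F)F)cc(C(F)(F)F)c1` gives 3200 nM in a toxicity assay on MCF-10A cells (Homo sapiens) for inhibition, read by MTT assay, with a stated time of 72 h; a higher number here means a weaker inhibitor of growth, a lower number a stronger inhibitor of growth.
Compound 1 `CC(C)(C)c1ccc(CNCCNS(=O)(=O)c2cc(C(F)(F)F)cc(C(F)(F)F)c2)cc1` gives 14000 nM in this assay.

Among the measured compounds shown here, compound 2 stands with the lower of the two numbers; the gap to compound 1, its only neighbour, lies beyond the usual scatter, so compound 2 is the stronger inhibitor of growth here. Compound 3 `COc1cccc(CNCCCNS(=O)(=O)c2cc(C(F)(F)F)cc(C(F)(F)F)c2)c1` has not yet been measured. It differs from compound 2 in one place: (3-methoxybenzyl)amino in place of ((4-bromobenzyl)amino)methyl on a saturated chain carbon, three bonds along the chain from a sulfonamide nitrogen. For the measured compounds named here, no measured pair shows this change on its own, so nothing measured tells how large its effect is. The step of a 2.0-fold higher number from compound 2 to compound 3 (0.31 log units; beyond the scatter) is expected to be modest, toward a higher number, close to the edge of the scatter. Compound 3 is expected to give 6500 nM, within a range from 2500 nM to 18000 nM.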

Compound 3, concentration for 50% growth inhibition: 6600 nM
The estimate for compound 3 lay 1.0-fold (0.01 log units) below the measured number; measured number inside the range.
By their numbers in this assay, from the lowest: compound 2; then compound 3; then compound 1.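

In this assay the change gives a 2.1-fold higher number from compound 2 to compound 3 (0.31 log units; beyond the scatter) and so shows that this position responds to replacing ((4-bromobenzyl)amino)methyl with (3-methoxybenzyl)amino. The two groups have the same count of heavy atoms, but the entering one carries oxygen instead of bromine and has one more hydrogen-bond acceptor. No independent measurement accounts for the shift. The change removes the methyl link and swaps bromo for methoxy together, and the compounds shown do not separate these two parts. On these data alone, whether a nitrile on the benzyl ring would move the number also remains open.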